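A few compounds are considered here, and "the series" means these few. Any claim that something is new, unique, unknown or untested is made for them only; others in the source may bear on it.

Three compounds of the series have numbers in a functional assay on HeLa cells (Homo sapiens) for inhibition; a higher number here means a weaker inhibitor, a lower number a stronger inhibitor. Compound 1 `Oc1cccc(-c2cc(-c3ccccc3F)cc(-c3ccccc3O)n2)c1` gives 31100 nM; compound 2 `Oc1cccc(-c2cc(-c3ccccc3C(F)(F)F)cc(-c3ccccc3O)n2)c1` gives 16800 nM; compound 3 `Oc1cccc(-c2cc(-c3cccc(C(F)(F)F)c3)cc(-c3ccccc3O)n2)c1` gives 19500 nM. Compound 3 stands second highest of the three, nearest to compound 2 and furthest from compound 1, and every step among them, a 1.9-fold lower number from compound 1 to compound 2 (0.27 log units; within the scatter), a 1.6-fold lower number from compound 1 to compound 3 (0.20 log units; within the scatter) and a 1.2-fold higher number from compound 2 to compound 3 (0.06 log units; within the scatter), lies within the scatter. Compound 4 `Oc1ccc(-c2cc(-c3cccc(C(F)(F)F)c3)cc(-c3cccc(O)c3)n2)cc1` differs from compound 3 by 4-hydroxyphenyl in place of 2-hydroxyphenyl on an aromatic carbon. For the measured compounds named here, no measured step touches this hydroxyphenyl group; the three steps all concern the other aryl substituent, and none left the scatter. No step beyond the scatter is therefore expected in this assay. For compound 4 the expected value is 19500 nM, within 6500 nM to 60000 nM, which is expected to mean no change at the digits printed from compound 3 to compound 4 (within the scatter).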

Compound 4, half-maximal inhibitory concentration: 16200 nM
The estimate for compound 4 lay 1.2-fold (0.08 log units) above the measured number, within the range that was stated.
By their numbers in this assay, from the lowest: compounds 4, 2, 3 and 1 (each within the scatter of the next).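

In this assay, for the compounds shown here, the first measured step at this position, next to the ring nitrogen, is a 1.2-fold lower number from compound 3 to compound 4 (0.08 log units; within the scatter) for 4-hydroxyphenyl in place of 2-hydroxyphenyl. The two compounds cannot be told apart, so within this pair a number of this size does not depend on the 2-hydroxyphenyl group. No measurement on hand bears on the reason for this.

On these data alone, whether any group at this position gives a step beyond the scatter remains open. An aminophenyl or carboxyphenyl group here, or an amine in place of the hydroxyl on the 3-hydroxyphenyl group, would test this.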